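Shortening the Side Chain of Compound 3

The source may report more compounds than this note shows. Statements on the series, on what has been measured and on what is new or still open speak of the compounds shown alone.

Three compounds have numbers so far in an ADME assay on microsomes from liver (Homo sapiens) for metabolic stability, with a stated time of 60 min, tested at 1 uM (on this read-out higher numbers stand for a more stable compound and lower numbers for a less stable compound), as follows
- compound 1 `COc1cc(-c2cnn3cc(OC)c(-c4cc(C)no4)nc23)ccn1` gives 31%
- compound 2 `COc1cc(-c2cnn3cc(OC)c(C)nc23)ccn1` gives 44%
- compound 3 `Cn1cc(-c2nc3c(-c4ccnc(OC5CC5)c4)cnn3cc2OCCCC(C)(C)O)cn1` gives 54%

Compound 3 lies clearly above compound 1, by more than the usual scatter, while its gap to compound 2 falls within that scatter. The next compound, compound 4 `Cn1cc(-c2nc3c(-c4ccnc(OC5CC5)c4)cnn3cc2OCC(C)(C)O)cn1`, differs from compound 3 in one place, on a saturated chain carbon bound to an oxygen on an aromatic ring. The change is 1-hydroxy-1-methylethyl in place of 3-hydroxy-3-methylbutyl on a saturated chain carbon bound to an oxygen on an aromatic ring and, cut one bond further out, it reads 4-hydroxy-4-methylpentyl to 2-hydroxy-2-methylpropyl.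

Going by the values given here, only one measured step compares two compounds that differ in one place. That step is a number 13 percentage points higher from compound 1 to compound 2 (beyond the scatter) and it is modest. It swaps 3-methyl-1,2-oxazol-5-yl for methyl on an aromatic carbon, so it is a different change at a different place and offers only a rough sense of size. Among the compounds with values here, no measured pair tests this chain, so the best anchor is compound 3 at 54% and no shift beyond the scatter is expected in this assay here. The expected move is a number 4 percentage points higher from compound 3 to compound 4 (within the scatter) and this estimate stays within the scatter. Compound 4 is estimated at 58% with an expected range of 40% to 76% around that middle.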

Compound 4, percent of the compound remaining: 53%
Compound 4: the middle estimate sits 5 percentage points above what was measured, and the stated range covers the measured number.
By their numbers in this assay, from the lowest: compound 1; then compounds 2, 4 and 3 (each within the scatter of the next).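

Going by these compounds alone, this is the first measured step that tests the chain itself: replacing 3-hydroxy-3-methylbutyl (6 heavy atoms) with 1-hydroxy-1-methylethyl (4 heavy atoms), on a saturated chain carbon bound to an oxygen on an aromatic ring, gives in this assay a number 1 percentage points lower from compound 3 to compound 4 (within the scatter). For this pair, then, removing those atoms while keeping the hydroxy group and its two flanking methyl groups leaves a difference that this assay cannot separate from ordinary repeat-to-repeat variation. No measurement is available to explain why the two chains read alike.

The compounds shown leave open how this assay would respond if the hydroxy group at the end of the chain gave way to an amine or a carboxylic acid, or if the chain were replaced by a simple methyl or by something longer than 4-hydroxy-4-methylpentyl. They also leave open whether the same shortening would read alike with a group other than cyclopropyloxy on the pyridine-like ring's side of the molecule, as compound 3 and compound 4 share everything outside the chain.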